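A few compounds are considered here, and "the series" means these few. Any claim that something is new, unique, unknown or untested is made for them only; others in the source may bear on it.

Three compounds have so far been measured in a functional assay on CHO cells for antagonist activity at sphingosine 1-phosphate receptor 2 (Homo sapiens), read by GTPgammaS binding; a higher number here means a weaker inhibitor, a lower number a stronger inhibitor:

compound 1 `CCOc1cc2[nH]c(Cc3nn(CC(=O)N4CCOCC4)c(=O)c4ccccc34)nc2cc1Cl`: 22 nM
compound 2 `CCn1nc(CC(=O)Nc2ccc(OC(F)(F)F)c(Cl)c2)c2ccccc2c1=O`: 473 nM
compound 3 `CC(C(=O)O)c1nn(Cc2cn3cc(OCC4CC4)c(Cl)cc3n2)c2ccccc2c1=O`: 31 nM

Compound 3 sits close to compound 1, the two numbers lying within the usual scatter of each other, so no order between them can be claimed. Compound 2, by contrast, gives a number well above that of compound 3, a gap that lies beyond the scatter. Compound 2 also differs from compound 3 in more than one place, so no single structural step can be read from that pair.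

Compound 4 `CC(C)(C(=O)O)c1nn(Cc2cn3cc(OCC4CC4)c(Cl)cc3n2)c2ccccc2c1=O` differs from compound 3 in one place: methyl in place of hydrogen on a saturated chain carbon bound to an aromatic carbon, a carbonyl carbon and a saturated chain carbon. Among the compounds with values here, no measured pair in this set isolates such a change, so there is no step to lean on. A single methyl added at a chain carbon of this kind is expected to move the number in this assay only a little, if at all, with a slight lean toward a weaker inhibitor. The step from compound 3 to compound 4 is therefore estimated as a 1.5-fold higher number from compound 3 to compound 4 (0.16 log units; within the scatter), and compound 4 is expected to give about 45 nM, within a range of 15 nM to 150 nM.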

Compound 4, half-maximal inhibitory concentration: 105 nM
Compound 4: middle estimate off by 2.3-fold (0.37 log units), on the low side; measured number inside the range.
By their numbers in this assay, from the lowest: compounds 1 and 3 (each within the scatter of the next); then compound 4; then compound 2.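

In this assay the change from 1-carboxyethyl to 1-carboxy-1-methylethyl gives a 3.4-fold higher number from compound 3 to compound 4 (0.53 log units; beyond the scatter) and so shows that this saturated chain carbon, bound to an aromatic carbon, a carbonyl carbon and a saturated chain carbon, does not tolerate a methyl in place of hydrogen without loss. The earlier compounds shown here could not show this, as they differ from one another in more than one place and offered no single step to read. Nothing at hand explains the rise in the number.

The compounds shown leave open how an ethyl group or a fluorine on this chain carbon would read. They also leave open whether the same methyl would cost as much with a primary amide in place of the carboxylic acid.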